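This account rests on a few compounds, and the source may have more. Where it says the series, first, only, none or still open, it means among the compounds named here.

Measured compounds:
compound 1 `Cc1ccccc1Nc1nnc(Nc2nc(-c3ccc(Cl)cc3)cs2)s1`, 300 mg/kg
compound 2 `Cc1ccccc1Nc1nnc(Nc2nc(-c3ccc(Br)cc3)cs2)s1`, 300 mg/kg
compound 3 `COc1ccc(Nc2nnc(Nc3nc(-c4ccc(Br)cc4)cs3)s2)cc1`, 30 mg/kg

In a functional assay on the whole organism (strain albino) with Mus musculus as the target, in the maximal electroshock model, with a stated time of 0.5 h (a lower number here means that less compound is needed, a higher number that more compound is needed for the effect), compound 2 gives 300 mg/kg. It stands level with compound 1, since no change at the digits printed from compound 1 to compound 2 (within the scatter); together they hold the highest numbers of the three. Among the compounds with values here, compound 3 is the one clearly apart: a 10-fold lower number from compound 2 to compound 3 (1.00 log units; beyond the scatter), the only step here that goes beyond the scatter, and it comes with the change of the aryl group on the ring nitrogen, not with any change at the halogen.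

Compound 4 `Cc1ccccc1Nc1nnc(Nc2nc(-c3ccccc3)cs2)s1` has not yet been run in this assay. It differs from compound 2 by hydrogen in place of bromo on an aromatic carbon. Within the data shown here, the one measured step at this position, bromo in place of chloro from compound 1 to compound 2, left the number unchanged within the scatter. Among the measured compounds shown here, no measured pair removes the halogen altogether, so there is no direct precedent for hydrogen at this carbon; the nearest evidence is the flat step at the same place. The expectation is therefore a step of little or no size, no change at the digits printed from compound 2 to compound 4 (within the scatter), with a slight lean toward a higher number rather than a lower one. Compound 4 is estimated at 300 mg/kg, within 100 mg/kg to 1000 mg/kg.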

Compound 4, minimum effective dose: 300 mg/kg
Estimate against measurement, compound 4: no gap at the digits printed, and the stated range covers the measured number.
By their numbers in this assay, from the lowest: compound 3; then compounds 1, 2 and 4 (each within the scatter of the next).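

With the 4-bromophenyl to phenyl change, this aromatic carbon, para to a large group, now has a reference without a halogen: in this assay hydrogen in place of bromo gives no change at the digits printed from compound 2 to compound 4 (within the scatter), and hydrogen in place of chloro gives no change at the digits printed from compound 1 to compound 4 (within the scatter). The earlier compounds shown here only exchanged one halogen for another, whereas these steps show that, with the 2-methylphenyl group on the nitrogen, the halogen can be removed altogether without a change beyond the scatter, and chloro, bromo and hydrogen at this carbon cannot be told apart by this read-out. Nothing available bears on why this position behaves in this way.

Within the data shown here, open is whether the same carbon stays as flat with the 4-methoxyphenyl group of compound 3 on the nitrogen, the one change that has moved the number beyond the scatter. Also open, from the compounds shown here alone, is whether a non-halogen group at this carbon, such as an amine, a carboxylic acid or a methoxy group, would move the number away from the level of compound 4 at 300 mg/kg in either direction.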